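Ethoxy in place of methoxy on a triazole series

The source may report more compounds than this note shows. Statements on the series, on what has been measured and on what is new or still open speak of the compounds shown alone.

Compound 1 `COc1cccc(-c2ncnn2-c2cc(OC)c(OC)c(OC)c2)c1` gives > 10000 nM in a functional assay on K562 cells (Homo sapiens) for antiproliferative activity, read by MTT assay, with a stated time of 72 h (a higher number here means a weaker inhibitor, a lower number a stronger inhibitor), which is a limit of the assay rather than a number.
Compound 2 `CCOc1cccc(-c2ncnn2-c2cc(OC)c(OC)c(OC)c2)c1` gives > 10000 nM in this assay, again only a limit.
Compound 3 `COc1ccccc1-c1ncnn1-c1cc(OC)c(OC)c(OC)c1` gives > 10000 nM in this assay, also a limit.

All three values therefore sit at the limit of > 10000 nM in this assay, at which 3 of the 3 values shown sit. From compound 1 to compound 2 the change is methyl in place of hydrogen on a saturated chain carbon bound to an oxygen on an aromatic ring, and the step is a step that the two limits leave unreadable from compound 1 to compound 2. The two cores of compound 1 and compound 3 differ by 2-methoxyphenyl in place of 3-methoxyphenyl on an aromatic carbon, with a step that the two limits leave unreadable from compound 1 to compound 3. Compound 4 `CCOc1ccccc1-c1ncnn1-c1cc(OC)c(OC)c(OC)c1` has not yet been measured in this assay. It differs from compound 3 by methyl in place of hydrogen on a saturated chain carbon bound to an oxygen on an aromatic ring, the same change as from compound 1 to compound 2, at a place described in identical words. Compound 4 is expected to give about 20000 nM in this assay, most likely reported only as a limit, because compound 2 and compound 3 both sit at the limit of > 10000 nM in this assay, at which 3 of the 3 values shown sit. The expected step from compound 3 is estimated as a step that the limit leaves unreadable from compound 3 to compound 4.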

Compound 4, half-maximal inhibitory concentration: > 10000 nM
Compound 4: only a limit was reported (the forecaster's own chance of this, stated with the estimate: 85%); the middle value lies beyond the limit too.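

No step can be read from compound 3 to compound 4, because each gives only a limit: the limit of > 10000 nM in this assay, at which 4 of the 4 values shown sit.

Among these compounds, what the ethoxy and 2-methoxyphenyl changes do to activity in this assay stays open, with no compound here giving an actual number.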